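Aminothiophene ketone replacing the pyrrole in a quinoline enone series

This account rests on a few compounds, and the source may have more. Where it says the series, first, only, none or still open, it means among the compounds named here.

Measured compounds: compound 1 `COc1ccc(-c2cc3ccccc3nc2/C=C/C(=O)c2ccco2)cc1` gives 640 nM; compound 2 `COc1ccc(-c2cc3ccccc3nc2/C=C/C(=O)c2ccccn2)cc1` gives 370 nM; compound 3 `COc1ccc(-c2cc3ccccc3nc2/C=C/C(=O)c2ccc[nH]2)cc1` gives > 10000 nM.

In a functional assay on SK-BR-3 cells (Homo sapiens) for antiproliferative activity, read by XTT assay, with a stated time of 72 h (a higher number here means a weaker inhibitor, a lower number a stronger inhibitor), compound 1 and compound 2 sit close together, the step of a 1.7-fold lower number from compound 1 to compound 2 (0.24 log units; within the scatter) staying within the scatter. Compound 3 stands apart: its value is only a limit of the assay, (the limit of > 10000 nM in this assay, at which 1 of the 3 values shown sits). The steps toward it are large, an at least 15-fold higher number from compound 1 to compound 3 (1.19 log units; beyond the scatter) and an at least 27-fold higher number from compound 2 to compound 3 (1.43 log units; beyond the scatter), so within this set the pyrrole ketone is the weakest compound.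

Compound 4 `COc1ccc(-c2cc3ccccc3nc2/C=C/C(=O)c2sccc2N)cc1` carries the change (3-aminothiophen-2-yl in place of 1H-pyrrol-2-yl on a carbonyl carbon). Among the measured compounds shown here, no measured step covers a 3-aminothiophen-2-yl group, so the two large steps into compound 3 are the only guide: both five-membered and six-membered rings without a ring hydrogen-bond donor gave numbers far below the limit. Compound 4 is therefore expected to move away from the limit, with the step of an at least 3.3-fold lower number from compound 3 to compound 4 (0.52 log units; beyond the scatter) estimated in the direction of a lower number, though its size is uncertain. Compound 4 is estimated at 3000 nM, in the range 600 nM to 15000 nM.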

Compound 4, half-maximal inhibitory concentration: > 10000 nM
Compound 4: only a limit was reported; the forecaster's own chance of this, stated with the estimate: 30%; middle value at least 3.3-fold (0.52 log units) away from the limit.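

Compound 4, like compound 3, ends at a limit of this assay and not at a number: the limit of > 10000 nM in this assay, at which 2 of the 4 values shown sit.

Replacing 1H-pyrrol-2-yl with 3-aminothiophen-2-yl therefore shows no gain in this assay, although the step between these two compounds cannot be read. Compound 4 also stands far from the other two, with an at least 27-fold higher number from compound 2 to compound 4 (1.43 log units; beyond the scatter) and an at least 15-fold higher number from compound 1 to compound 4 (1.19 log units; beyond the scatter). Among these four compounds, a second ring type carrying a hydrogen-bond donor thus falls with the pyrrole ketone and not with the furan-2-yl and pyridin-2-yl ketones, and no compound shown goes against this.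

On these data alone, it remains open whether the donor itself matters, since the rings also differ in other ways. A plain thiophen-2-yl group or a 1-methylpyrrol-2-yl group on the same carbonyl carbon would test this.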